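This account rests on a few compounds, and the source may have more. Where it says the series, first, only, none or still open, it means among the compounds named here.

Of the compounds shown here, two carrying the same core have been measured in an assay on CHO cells for displacement of a labelled ligand from muscarinic acetylcholine receptor M5 (Homo sapiens), read by scintillation counting, with a stated time of 2 h; a lower number here means a stronger inhibitor, a higher number a weaker inhibitor. Compound 1, `O=C(OCCc1ccc(Cl)c(Cl)c1)N(c1ccccc1)C1CN2CCC1CC2`, gives 80 nM in this assay. Going by the values given here, compound 2, `COc1ccc(CCCOC(=O)N(c2ccccc2)C2CN3CCC2CC3)cc1OC`, gives 1610 nM in this assay, the highest of the two numbers, and the only other number, that of compound 1, lies beyond the scatter below it. Compound 3, `O=C(OCCCc1ccc(Cl)c(Cl)c1)N(c1ccccc1)C1CN2CCC1CC2`, is built from compound 2 by one change: 3,4-dichlorophenyl in place of 3,4-dimethoxyphenyl on a saturated chain carbon, three bonds along the chain from an oxygen next to a carbonyl group. Among the compounds with values here, no direct pair of measured compounds isolates this change, but compound 1, which carries the same 3,4-dichlorophenyl on a shorter chain, is the stronger binder of the two, with 80 nM in this assay. On that basis compound 3 is expected to lie closer to compound 1 than to compound 2, the estimated step being an 11-fold lower number from compound 2 to compound 3 (1.03 log units; beyond the scatter). The expected value for compound 3 in this assay is 150 nM, within a range from 40 nM to 600 nM.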

Compound 3, inhibition constant: 130 nM
Estimate against measurement, compound 3: 1.2-fold (0.06 log units) above; measured number inside the range.
By their numbers in this assay, from the lowest: compounds 1 and 3 (each within the scatter of the next); then compound 2.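

In this assay, the step of a 12-fold lower number from compound 2 to compound 3 (1.09 log units; beyond the scatter) shows that 3,4-dichlorophenyl in place of 3,4-dimethoxyphenyl, on a saturated chain carbon, three bonds along the chain from an oxygen next to a carbonyl group, is a large change on an otherwise unchanged structure. The other step, a 1.6-fold higher number from compound 1 to compound 3 (0.21 log units; within the scatter), shows that with the two chlorines kept, 3,4-dichlorobenzyl and 3,4-dichlorophenyl at their place on the chain are not told apart in this assay. Nothing shown gives a reason for the large step.

Open, from the compounds shown here alone, is whether a single chlorine or a single methoxy group at the end of the chain would account for that step, or an unsubstituted phenyl ring would match either pair. Also open, going by these compounds, is whether a longer chain would still leave the number unchanged.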